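Solubility of a Furanyl-Pyridine Series: Sulfonyl Replacing Methyl

A few compounds are considered here, and "the series" means these few. Any claim that something is new, unique, unknown or untested is made for them only; others in the source may bear on it.

Compound 1 `N#Cc1ccc(-c2cc(-c3ccccc3)cc(-c3ccco3)n2)cc1`: 2000 nM
Compound 2 `CNC(=O)c1ccc(-c2cc(-c3ccc(C#N)cc3)nc(-c3ccco3)c2)cc1`: 25000 nM

Within the data shown here, compound 2 gives the higher of the two numbers in a physicochemical assay for solubility, at pH 6; on this read-out lower numbers stand for lower solubility and higher numbers for higher solubility; the only measured step, a 13-fold higher number from compound 1 to compound 2 (1.10 log units; beyond the scatter), shows what adding methylcarbamoyl did. Compound 3 `CS(=O)(=O)NC(=O)c1ccc(-c2cc(-c3ccc(C#N)cc3)nc(-c3ccco3)c2)cc1` differs from compound 2 by methylsulfonyl in place of methyl on an amide-type nitrogen. Among the measured compounds shown here, no measured step tests this exchange on the amide nitrogen, so the expectation leans only on the direction seen when that substituent was first introduced, and the range is kept wide. For compound 3 the estimated step is a 2.0-fold higher number from compound 2 to compound 3 (0.30 log units; within the scatter), giving an expected value of 50000 nM, between 12000 nM and 200000 nM.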

Compound 3, solubility: 32000 nM
The estimate for compound 3 lay 1.6-fold (0.19 log units) above the measured number, within the range that was stated.
By their numbers in this assay, from the lowest: compound 1; then compounds 2 and 3 (each within the scatter of the next).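

In this assay, methylsulfonyl in place of methyl on the amide-type nitrogen gives a 1.3-fold higher number from compound 2 to compound 3 (0.11 log units; within the scatter), so this exchange, despite the larger group, separates the two compounds by no more than ordinary scatter. Measured against hydrogen on the aromatic carbon, the (methylsulfonyl)carbamoyl group still gives a 16-fold higher number from compound 1 to compound 3 (1.20 log units; beyond the scatter), which is large and runs the same way as the step seen with methylcarbamoyl. No measurement here explains why these two groups read alike.

Still open, from the compounds shown here alone, is how a carboxylic acid on that aromatic carbon would read. Equally open, going by these compounds, is whether a longer chain on the amide-type nitrogen would stay within the scatter of compound 2.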